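Swapping the carbamate ester group on a shared core

This account rests on a few compounds, and the source may have more. Where it says the series, first, only, none or still open, it means among the compounds named here.

Two compounds share one core and differ only in the groups hung on it. Compound 1 `CC1(COC(=O)N2CC3COCC(C2)C3Oc2ncnc(Nc3ccc(C#N)cc3Cl)c2F)COC1` is the weaker of the pair: in a functional assay on HEK293 cells for agonist activity at Glucose-dependent insulinotropic receptor (Homo sapiens), read by cAMP accumulation, with a stated time of 30 min (on this read-out higher numbers stand for an effect only at larger amounts of compound and lower numbers for an effect already at smaller amounts), compound 1 gives 188 nM, the highest number among the two. Compound 2 `CCC1(OC(=O)N2CC3COCC(C2)C3Oc2ncnc(Nc3ccc(C#N)cc3F)c2F)CC1` differs from compound 1 in several places. In this assay compound 2 gives 6 nM, a gap stated to lie beyond the usual scatter.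

Compound 3 `N#Cc1ccc(Nc2ncnc(OC3C4COCC3CN(C(=O)OC3CCC3)C4)c2F)c(Cl)c1` is not yet measured. It arises from compound 1 by one change: cyclobutyl in place of (3-methyloxetan-3-yl)methyl on an oxygen next to a carbonyl group. Going by the values given here, no measured pair shows this change on its own, so its effect can only be estimated. Because compound 2, which also carries a ring carbon directly on that oxygen, gives 6 nM, a move toward smaller numbers is expected, of the size a 3.8-fold lower number from compound 1 to compound 3 (0.58 log units; beyond the scatter). Compound 3 is therefore estimated at 50 nM, within a range from 15 nM to 160 nM.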

Compound 3, half-maximal effective concentration: 10 nM
For compound 3 the middle estimate is 5.0-fold (0.70 log units) above the measured one; measured number below the stated range.
By their numbers in this assay, from the lowest: compounds 2 and 3 (each within the scatter of the next); then compound 1.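

Read on its own, the swap of (3-methyloxetan-3-yl)methyl for cyclobutyl on an oxygen next to a carbonyl group gives a 19-fold lower number from compound 1 to compound 3 (1.27 log units; beyond the scatter) in this assay and is the only difference between these two compounds. The earlier gap between compound 1 and compound 2 came with several differences at once, so it could not be tied to any one place, whereas this step shows that the group at this position can by itself shift the number by a large amount. Nothing shown here explains why the step is so large.

This single swap changes the ring and its attachment together, so it cannot tell which of those changes matters. On these data alone, an oxetan-3-yl ring or a cyclobutylmethyl group on the same oxygen would separate the two, and how either would behave remains open.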